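A few compounds are considered here, and "the series" means these few. Any claim that something is new, unique, unknown or untested is made for them only; others in the source may bear on it.

Measured in a functional assay on RAW264.7 cells (Mus musculus) for inhibition, read by Griess assay, with stated times of 1 h and 24 h; on this read-out lower numbers stand for stronger inhibition and higher numbers for weaker inhibition:
- compound 1 `O=C1OC(Cc2nc(-c3ccccc3)no2)c2ccccc21`: > 10000 nM
- compound 2 `O=C1OC(Cc2nc(Cc3ccccc3)no2)c2ccccc21`: > 10000 nM
- compound 3 `CCOc1ccc(C(O)C2OC(=O)c3c(OC)cc(OC)cc32)cc1`: > 10000 nM

Each of these values is a limit of the assay and not a number. Going by these compounds, compound 3 stands at the limit of > 10000 nM in this assay, at which 3 of the 3 values shown sit, so its true position is unknown.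

Compound 4 `COCCOc1ccc(C(O)C2OC(=O)c3c(OC)cc(OC)cc32)cc1` is compound 3 with one change: methoxy in place of hydrogen on a saturated chain carbon, two bonds along the chain from an oxygen on an aromatic ring. Cut one bond further out, this reads ethoxy to 2-methoxyethoxy.

For the measured compounds named here, the only measured step is a step that the two limits leave unreadable from compound 1 to compound 2, with benzyl in place of phenyl on an aromatic carbon. Going by the values given here, it supplies no size to carry over, and no measured step covers this change. No step beyond the scatter is therefore expected in this assay, and no direction is favoured. The estimated step is a step that the limit leaves unreadable from compound 3 to compound 4, and this is only a loose expectation. The most likely report is another limit. Compound 4 is estimated at 12000 nM, with an expected range of 4000 nM to 30000 nM.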

Compound 4, half-maximal inhibitory concentration: > 10000 nM
Compound 4: only a limit was reported; the forecaster's own chance of this, stated with the estimate: 70%; the middle value does not contradict the limit.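

In this assay compound 4 gives > 10000 nM, which is a limit and not a number, so no step can be read from compound 3 to compound 4. The compounds shown leave open how strongly each inhibits and whether either structural change moves the read-out, since all share one limit: the limit of > 10000 nM in this assay, at which 4 of the 4 values shown sit.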